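Series notes: the step from compound 1 to compound 4

The compounds below may be only part of what the source reports. "The series", "measured", "known", "first", "only" and "open" are said of these compounds alone.

Within the data shown here, compound 1 `C=C(Br)C(=O)Nc1ccc(/C=C/C(=O)c2ccc(F)cc2)cc1` gives 1100 nM in an ADME assay on CCRF-CEM cells (Homo sapiens) for antiproliferative activity, with a stated time of 48 h (on this read-out lower numbers stand for stronger inhibition and higher numbers for weaker inhibition), the second highest of the three numbers so far. Compound 2 `C=C(Br)C(=O)Nc1ccc(/C=C/C(=O)c2ccc(Cl)cc2)cc1` gives 950 nM and compound 3 `C=C(Br)C(=O)Nc1ccc(/C=C/C(=O)c2ccc(OC)cc2)cc1` gives 1400 nM. The steps of a 1.2-fold lower number from compound 1 to compound 2 (0.06 log units; within the scatter), a 1.3-fold higher number from compound 1 to compound 3 (0.10 log units; within the scatter) and a 1.5-fold higher number from compound 2 to compound 3 (0.17 log units; within the scatter) all lie within the scatter, so none of the three compounds is set apart from the others on this read-out.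

Compound 4 `C=C(Br)C(=O)Nc1ccc(/C=C/C(=O)c2cccc(OC)c2)cc1` differs from compound 1 by 3-methoxyphenyl in place of 4-fluorophenyl on a carbonyl carbon. Among the measured compounds shown here, the closest precedent is the replacement of fluoro by methoxy on an aromatic carbon, which gave a 1.3-fold higher number from compound 1 to compound 3 (0.10 log units; within the scatter). For the measured compounds named here, no measured pair compares the two ring positions of the methoxy group, so that part of the change has no precedent in the data. The expected step is therefore a 1.2-fold higher number from compound 1 to compound 4 (0.07 log units; within the scatter), with no direction favoured beyond the scatter. Compound 4 is estimated at 1300 nM, with a range from 600 nM to 2800 nM.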

Compound 4, half-maximal inhibitory concentration: 2300 nM
Compound 4: middle estimate off by 1.8-fold (0.25 log units), on the low side; low and high end bracket the measured number.
By their numbers in this assay, from the lowest: compounds 2, 1, 3 and 4 (each within the scatter of the next, the first and the last beyond it).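

In this assay, among these compounds, 3-methoxyphenyl in place of the earlier aryl groups on the carbonyl carbon gives the first steps that leave the scatter: a 2.1-fold higher number from compound 1 to compound 4 (0.32 log units; beyond the scatter) and a 2.4-fold higher number from compound 2 to compound 4 (0.38 log units; beyond the scatter), both modest. The one pair that isolates the ring position of the methoxy group stays within the scatter, at a 1.6-fold higher number from compound 3 to compound 4 (0.22 log units; within the scatter), so ring position alone is not shown to matter and compound 3 and compound 4 cannot be told apart. Compound 4 is separated from compound 1 and compound 2 only by the combined change of group and ring position, and nothing available here accounts for that separation.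

Open is whether an amine or a carboxylic acid on that ring, or a longer chain in place of the methoxy group, would move the number beyond the scatter from all of these compounds. Also open, on these data alone, is whether the same order holds on any read-out other than this assay.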